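The source may report more compounds than this note shows. Statements on the series, on what has been measured and on what is new or still open speak of the compounds shown alone.

Measured so far:
Compound 1 `CCOC(=O)C(=O)Nc1ccccc(Oc2ccccc2)c1=O`: 9%
Compound 2 `CCOC(=O)C(=O)Nc1ccccc(OC)c1=O`: 56%

For the measured compounds named here, of the two numbers measured in a functional assay on the whole organism (strain Sprague-Dawley CD) for inhibition, with Rattus norvegicus as the target, read by paw edema, at a dose of 100 mg/kg by the oral route (on this read-out higher numbers stand for a stronger effect at the one dose given and lower numbers for a weaker effect), compound 2 stands highest, and compound 1, its only neighbour, sits far below it: a number 47 percentage points higher from compound 1 to compound 2 (beyond the scatter). Compound 3 `CCOC(=O)C(=O)Nc1ccccc(-c2ccccc2)c1=O` has not yet been measured. Going by the values given here, it differs from compound 2 in one place: phenyl in place of methoxy on an aromatic carbon The one measured step bears on this change only in part. Going from compound 1 to compound 2 took away a phenyl on an oxygen and left a methoxy, and that step was large in favour of compound 2. Compound 3 brings a phenyl back, now placed on an aromatic carbon with no oxygen between, so it resembles compound 1 in the size of the group it carries but not in the way that group is joined. On that basis a fall is expected, of a size a number 34 percentage points lower from compound 2 to compound 3 (beyond the scatter), though with a single step to lean on the direction is more certain than the amount. For compound 3 the estimate is 22%, between 0% and 48%.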

Compound 3, a percentage reported as inhibition, in the whole organism at one dose (the size of the read-out at that dose, not a potency): 0%
Estimate against measurement, compound 3: 22 percentage points above; low and high end bracket the measured number.
By their numbers in this assay, from the lowest: compounds 3 and 1 (each within the scatter of the next); then compound 2.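

In this assay, the change from methoxy to phenyl on an aromatic carbon of the seven-membered aromatic ring gives a number 56 percentage points lower from compound 2 to compound 3 (beyond the scatter), so a phenyl on this carbon goes with a low read-out even when no oxygen joins it to the ring. The two phenyl-bearing compounds cannot be told apart, with a number 9 percentage points lower from compound 1 to compound 3 (within the scatter), which means the linking oxygen of the phenoxy group makes no readable difference here. Of the three groups shown, only methoxy stands clear of the others, and nothing at hand gives a reason for this.

The compounds shown leave open what happens with other groups at this carbon: an ethoxy or a longer chain would show how far the oxygen-linked chain can grow before the effect is lost, while a hydroxyl or an amine would show whether methoxy is unusual among small groups. For the compounds shown here, with only three compounds, each tested at a single dose, it also remains open how these read-outs would change at other doses.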